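Fluorobenzyl isomers: from compound 3 to compound 4

This account rests on a few compounds, and the source may have more. Where it says the series, first, only, none or still open, it means among the compounds named here.

- compound 1 `CC(C)(C)c1cc(/C=C/C(=O)NCCC2CCN(Cc3ccccc3)CC2)cc(C(C)(C)C)c1O`: 81700 nM
- compound 2 `Cc1ccccc1CN1CCC(CCNC(=O)/C=C/c2cc(C(C)(C)C)c(O)c(C(C)(C)C)c2)CC1`: 65300 nM
- compound 3 `CC(C)(C)c1cc(/C=C/C(=O)NCCC2CCN(Cc3ccccc3F)CC2)cc(C(C)(C)C)c1O`: 55900 nM
- compound 4 `CC(C)(C)c1cc(/C=C/C(=O)NCCC2CCN(Cc3cccc(F)c3)CC2)cc(C(C)(C)C)c1O`: not yet measured

In a functional assay, read by spectrophotometry, with a stated time of 30 min (a lower number here means a stronger inhibitor, a higher number a weaker inhibitor), compound 3 gives 55900 nM, a value not separated from the other two: a 1.2-fold lower number from compound 2 to compound 3 (0.07 log units; within the scatter) and a 1.5-fold lower number from compound 1 to compound 3 (0.16 log units; within the scatter) both lie within the scatter.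

The change under study is 3-fluorophenyl in place of 2-fluorophenyl on a saturated chain carbon bound to an amine nitrogen in a ring. For the measured compounds named here, no measured pair covers this change directly, so the evidence is indirect. Adding a fluoro group gave a 1.5-fold lower number from compound 1 to compound 3 (0.16 log units; within the scatter), adding a methyl group gave a 1.3-fold lower number from compound 1 to compound 2 (0.10 log units; within the scatter), and exchanging the methyl group for a fluoro group gave a 1.2-fold lower number from compound 2 to compound 3 (0.07 log units; within the scatter). None of these steps leaves the scatter. Going by the values given here, only three compounds stand behind this reading, and fluoro has been measured at only one place.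

No step beyond the scatter, in either direction, is therefore expected in this assay. The estimate amounts to an expected 1.1-fold higher number from compound 3 to compound 4 (0.03 log units; within the scatter). For compound 4 the estimated value is 60000 nM, with an expected range of 30000 nM to 120000 nM.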

Compound 4, half-maximal inhibitory concentration: 55200 nM
Compound 4: the middle estimate sits 1.1-fold (0.04 log units) above what was measured, within the range that was stated.
By their numbers in this assay, from the lowest: compounds 4, 3, 2 and 1 (each within the scatter of the next).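

In this assay, for the compounds shown here, the shift from 2-fluorobenzyl to 3-fluorobenzyl gives the first direct reading of where fluoro sits on this group, and a 1.0-fold lower number from compound 3 to compound 4 (0.01 log units; within the scatter) shows that these two isomers cannot be told apart. Neither a 1.2-fold lower number from compound 2 to compound 4 (0.07 log units; within the scatter) nor a 1.5-fold lower number from compound 1 to compound 4 (0.17 log units; within the scatter) leaves the scatter, so compound 1, compound 2, compound 3 and compound 4 all remain within the scatter of one another, and the small substituent changes at this position have so far produced no separation. No supporting measurement is available to explain this flat reading.

On these data alone, it remains open whether a different kind of group on the benzyl ring, such as an amine or a carboxylic acid, or a longer chain in place of the benzyl carbon on the amine nitrogen in the ring, would produce a step beyond the scatter. Every change shown here lies at this one position, so these compounds also leave open whether changes elsewhere on the shared core would move the number in this assay further than these substitutions have.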